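Three measured compounds and one expected methoxy addition

The source may report more compounds than this note shows. Statements on the series, on what has been measured and on what is new or still open speak of the compounds shown alone.

Measured so far:
compound 1, `Fc1ccccc1/C=C/c1ccccc1`: 700 nM
compound 2, `COc1ccccc1/C=C/c1ccccc1F`: 3100 nM
compound 3, `COc1cccc(/C=C/c2ccc(F)cc2)c1`: 6000 nM

All three were run in an assay on HepG2 cells for activation of nuclear factor erythroid 2-related factor 2 (Homo sapiens), read by a luciferase reporter, with a stated time of 5 h; on this read-out higher numbers stand for an effect only at larger amounts of compound and lower numbers for an effect already at smaller amounts. Compound 1 gives 700 nM, and compound 2, which carries one extra group on the shared core, gives 3100 nM. The difference between the two is methoxy in place of hydrogen on an aromatic carbon, and the step is a 4.4-fold higher number from compound 1 to compound 2 (0.65 log units; beyond the scatter). Compound 3 gives 6000 nM; its value and that of compound 2 lie within the scatter of each other, so no order between them is claimed. Against compound 1, compound 3 stands beyond the scatter. How the core of compound 3 differs from the core of compound 1 is not broken down here.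

Compound 4, `COc1cccc(/C=C/c2ccc(F)cc2)c1OC`, has not been measured. It differs from compound 3 by methoxy in place of hydrogen on an aromatic carbon. Among the measured compounds shown here, this is the same kind of change as the one from compound 1 to compound 2, with one difference around the place: in compound 4 the entering methoxy is also ortho to a methoxy group, whereas in compound 2 it is ortho only to the group of 9 heavy atoms. The one earlier occurrence moved the number upward by more than the scatter, and compound 3 already stands at the high end of the series, so a further rise is expected. Beside the earlier step, the step from compound 3 to compound 4 in this assay is estimated at a 2.5-fold higher number from compound 3 to compound 4 (0.40 log units; beyond the scatter), taken somewhat smaller than the measured one because the surroundings are not identical and the single step of a 4.4-fold higher number from compound 1 to compound 2 (0.65 log units; beyond the scatter) is the only evidence. Compound 4 is therefore expected to give about 15000 nM, with a likely range from 5000 nM to 45000 nM.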

Compound 4, half-maximal effective concentration: 2900 nM
Compound 4: middle estimate off by 5.2-fold (0.71 log units), on the high side, and the stated range ends above it.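

In this assay, methoxy in place of hydrogen on an aromatic carbon gives a 2.1-fold lower number from compound 3 to compound 4 (0.32 log units; beyond the scatter), so on these two cores the change does not keep its direction, and the earlier step cannot serve as a transferable value for this series: the same change on two cores in this assay, a 4.4-fold higher number (0.65 log units; beyond the scatter) from compound 1 to compound 2 and a 2.1-fold lower number (0.32 log units; beyond the scatter) from compound 3 to compound 4, 9.2-fold (0.96 log units) apart, beyond the scatter of two such steps

The two occurrences differ in more than one respect: the entering methoxy in compound 4 is ortho to a methoxy group, while that in compound 2 is not, and the cores also differ elsewhere. Among the compounds shown here, with only this pair of steps, the notes can record that the outcome of the change depends on its setting, but they cannot assign the reversal to the neighbouring methoxy group, to the rest of the core, or to both, and they give no rule for a further core.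

The compounds shown carry only fluorine and methoxy as groups on the shared core, so it remains open whether a hydroxy group, an amine or a carboxylic acid in the same place would follow either step. Going by these compounds, it also remains open whether a longer chain such as ethoxy would behave as methoxy does on the core of compound 1 and on the core of compound 3.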